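Phenyl for cyclohexyl on the ring nitrogen, second core

The source may hold more compounds than are shown below. What is called first, only, known or untested is meant among the compounds shown, and "the series" means these compounds.

Compound 1 `CCN(CC)c1ccc(/C=C2\C(=O)N(C3CCCCC3)C(=S)N2C)c(OC)c1` and compound 2 `CCN(CC)c1ccc(/C=C2\C(=O)N(c3ccccc3)C(=S)N2C)c(OC)c1` share one core and differ only at an amide-type nitrogen in a ring; compound 3 `CN1C(=S)N(C2CCCCC2)C(=O)/C1=C\c1ccc(N(C)CCCO)cc1O` and compound 4 `CN1C(=S)N(c2ccccc2)C(=O)/C1=C\c1ccc(N(C)CCCO)cc1O` share a second core. How the two cores differ is not broken down here.

In an assay on isolated protein for inhibition of NADPH oxidase 4 (Homo sapiens), read by chemiluminescence, in the presence of a further agent that is not named here (on this read-out lower numbers stand for stronger inhibition and higher numbers for weaker inhibition), compound 1 gives 1340 nM. Compound 2 gives 1170 nM in this assay. The change between them, (phenyl in place of cyclohexyl on an amide-type nitrogen in a ring), made a step of a 1.1-fold lower number from compound 1 to compound 2 (0.06 log units; within the scatter), so the two values are indistinguishable on this read-out.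

Compound 3 gives 2500 nM in this assay. Among the compounds with values here, its value stands within the scatter of compound 1 and beyond the scatter of compound 2, a pair of comparisons that says little on its own given the one measured step on the first core.

Compound 4 carries the same change, (phenyl in place of cyclohexyl on an amide-type nitrogen in a ring), made on the second core. Compound 4 has not been measured in this assay. Because the one measured occurrence of this change gave a 1.1-fold lower number from compound 1 to compound 2 (0.06 log units; within the scatter), the step from compound 3 to compound 4 is expected to be small, a 1.1-fold lower number from compound 3 to compound 4 (0.04 log units; within the scatter). Whether a change that was flat on the first core stays flat on the second cannot be checked from these three compounds; the expectation rests only on that single step.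

For compound 4 in this assay the estimate is 2300 nM, with a likely range from 1100 nM to 4800 nM.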

Compound 4, half-maximal inhibitory concentration: 5020 nM
For compound 4 the middle estimate is 2.2-fold (0.34 log units) below the measured one; measured number above the stated range.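

In this assay, phenyl in place of cyclohexyl on an amide-type nitrogen in a ring gives a 2.0-fold higher number from compound 3 to compound 4 (0.30 log units; within the scatter) on the second core. Set beside the occurrence on the first core, the two steps cannot be told apart: the same change on two cores in this assay, a 1.1-fold lower number (0.06 log units; within the scatter) from compound 1 to compound 2 and a 2.0-fold higher number (0.30 log units; within the scatter) from compound 3 to compound 4, 2.3-fold (0.36 log units) apart, within the scatter of two such steps. The two pairs therefore give no sign that the outcome of this change depends on the core, and for now it can be carried between these two cores as a change with no clear effect on this read-out, but two pairs with this much scatter do not prove that it transfers, and a modest dependence on the core would look the same here.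

Open, from the compounds shown here alone, is whether the same holds for other groups on that nitrogen, such as a benzyl group, a short alkyl chain, or a phenyl ring bearing an amine or a carboxylic acid. Also open, going by these compounds, is what each part of the difference between the cores contributes, as compound 1 and compound 3 differ in more than one place and their values cannot be assigned to any single part.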